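Pyridin-3-yl to Pyridin-4-yl on a Weakly Cytotoxic Core

The source may hold more compounds than are shown below. What is called first, only, known or untested is meant among the compounds shown, and "the series" means these compounds.

Going by the values given here, compound 2 `Oc1cccc(-c2cc(-c3ccc(Cl)cc3)nc(-c3cccnc3)c2)c1` is the only compound with a number here; in a functional assay on T47D cells (Homo sapiens) for cytotoxicity, read by CCK-8 assay and cell counting, with a stated time of 2 days (on this read-out lower numbers stand for stronger inhibition and higher numbers for weaker inhibition), compound 2 gives 18100 nM. Compound 1 `Oc1cccc(-c2cc(-c3ccncc3)nc(-c3cccc(Cl)c3)c2)c1` has no result in this assay, where compound 1 is recorded as "not determined" (no result reported), so compound 2 stands alone. Compound 3 `Oc1cccc(-c2cc(-c3ccncc3)nc(-c3ccc(Cl)cc3)c2)c1` differs from compound 2 in one place: pyridin-4-yl in place of pyridin-3-yl on an aromatic carbon. Among the compounds with values here, with no step between measured compounds to draw on, this change is expected to shift this assay little, if at all, beyond the scatter in either direction. Compound 3 is therefore expected to give about 15000 nM, within 5000 nM to 45000 nM. That expectation amounts to an estimated step of a 1.2-fold lower number from compound 2 to compound 3 (0.08 log units; within the scatter).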

Compound 3, half-maximal inhibitory concentration: 3330 nM
For compound 3 the middle estimate is 4.5-fold (0.65 log units) above the measured one, and the stated range ends above it.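

Pyridin-4-yl in place of pyridin-3-yl keeps the same atoms and the same counted donors and acceptors, yet at this position on the shared core it is not a silent change: in this assay it gives a 5.4-fold lower number from compound 2 to compound 3 (0.74 log units; beyond the scatter). This place therefore responds to where the nitrogen sits within the attached ring alone. Nothing available here accounts for the step. Still open, from the compounds shown here alone, is how pyridin-2-yl, a plain phenyl or an aminopyridine at this place would compare with pyridin-4-yl.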